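Dimethylamino for hydroxy on the 2-hydroxypyridin-4-yl of compound 3

The source may hold more compounds than are shown below. What is called first, only, known or untested is meant among the compounds shown, and "the series" means these compounds.

Measured in an in vitro functional assay on HEK285-7 cells for antagonist activity at prostaglandin D2 receptor 2 (Homo sapiens), read by BRET and beta-arrestin recruitment; a higher number here means a weaker inhibitor, a lower number a stronger inhibitor:
compound 1 `O=C(O)Cc1sc(C(c2ccc(F)cc2)c2ccc(F)cc2)nc1-c1ccc(Cl)cc1` gives 180 nM
compound 2 `NS(=O)(=O)c1ccc(-c2nc(C(c3ccc(F)cc3)c3ccc(F)cc3)sc2CC(=O)O)cc1` gives > 100000 nM
compound 3 `O=C(O)Cc1sc(C(c2ccc(F)cc2)c2ccc(F)cc2)nc1-c1ccnc(O)c1` gives 890 nM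

Compound 3 stands highest of the two numbers shown in this assay. Its nearest neighbour is compound 1; the step of a 4.9-fold higher number from compound 1 to compound 3 (0.69 log units; beyond the scatter) is modest. For compound 2 this assay reports only a limit, (the limit of > 100000 nM in this assay, at which 1 of the 3 values shown sits). The step of an at least 550-fold higher number from compound 1 to compound 2 (2.74 log units; beyond the scatter) is large, as is the step of an at least 110-fold lower number from compound 2 to compound 3 (2.05 log units; beyond the scatter).

Compound 4 `CN(C)c1cc(-c2nc(C(c3ccc(F)cc3)c3ccc(F)cc3)sc2CC(=O)O)ccn1` differs from compound 3 in one place: dimethylamino in place of hydroxy on an aromatic carbon. Going by the values given here, no measured step changes the 2-hydroxypyridin-4-yl itself; the measured steps replace the whole aryl group or its para substituent, and the exchange of the hydroxy for dimethylamino has no direct precedent among the three compounds. With a chloro on the aryl group compound 1 gives the lowest number, with a sulfamoyl compound 2 only a limit. For compound 4 the expected value in this assay is 600 nM, between 150 nM and 2500 nM, which means an expected step of a 1.5-fold lower number from compound 3 to compound 4 (0.17 log units; within the scatter), within or barely beyond the scatter.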

Compound 4, half-maximal inhibitory concentration: > 100000 nM
Compound 4: a limit, no number; the forecaster's own chance of this, stated with the estimate: 5%; middle value at least 160-fold (2.22 log units) from the limit.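

Exchanging hydroxy for dimethylamino on the 2-hydroxypyridin-4-yl gives an at least 110-fold higher number from compound 3 to compound 4 (2.05 log units; beyond the scatter) in this assay. A change at this one aromatic carbon next to the ring nitrogen, and not only replacement of the whole aryl group or its para substituent, can therefore carry a compound out of the measurable range, and the comparison with the chloro compound reads an at least 550-fold higher number from compound 1 to compound 4 (2.74 log units; beyond the scatter). Compound 4, like compound 2, gives a limit and not a number, so the step between these two cannot be read: the limit of > 100000 nM in this assay, at which 2 of the 4 values shown sit.

Still open, on these data alone, is whether the outcome follows from the dimethylamino itself or from the absence of the hydroxy. An amino, a methylamino or a methoxy at this carbon would help separate the two, as would a plain hydrogen there.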